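This account rests on a few compounds, and the source may have more. Where it says the series, first, only, none or still open, it means among the compounds named here.

Three compounds sharing one core were tested in an ADME assay on RAW264.7 cells (Mus musculus) for cytotoxicity, read by MTT assay, with a stated time of 48 h, tested at 50 uM; on this read-out higher numbers stand for more inhibition at the one concentration tested (going by the name of the read-out) and lower numbers for less inhibition. Compound 1, `CC(C)(C)OC(=O)N1CCc2c(sc(NC(=O)c3ccc(Cl)cc3)c2C(N)=O)C1`, gives 37.3% in this assay. Compound 2, `NC(=O)c1c(NC(=O)c2ccc(Cl)cc2)sc2c1CCN(Cc1ccccc1)C2`, gives 11.1%, and compound 3, `CC(C)(C)OC(=O)N1CCc2c(sc(NC(=O)c3ccc(Oc4ccccc4)cc3)c2C(N)=O)C1`, gives 26.9%. Compound 3 differs from compound 1 by phenoxy in place of chloro on an aromatic carbon, which lowers the read-out by a number 10.4 percentage points lower from compound 1 to compound 3 (beyond the scatter). Compound 2 differs from compound 1 by benzyl in place of tert-butoxycarbonyl on an amine nitrogen in a ring, and that change lowers the read-out by a number 26.2 percentage points lower from compound 1 to compound 2 (beyond the scatter).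

Compound 4, `NC(=O)c1c(NC(=O)c2ccc(Oc3ccccc3)cc2)sc2c1CCN(Cc1ccccc1)C2`, has not yet been measured. It differs from compound 3 by benzyl in place of tert-butoxycarbonyl on an amine nitrogen in a ring, the same change that turned compound 1 into compound 2, made on the same place of the shared core. Among the compounds with values here, the step of a number 26.2 percentage points lower from compound 1 to compound 2 (beyond the scatter) is the only example of this change at hand, so the expectation for compound 4 rests on it alone: starting from compound 3 at 26.9%, a drop of similar size is expected, namely a number 23.9 percentage points lower from compound 3 to compound 4 (beyond the scatter). On that basis compound 4 is estimated to give 3% in this assay, expected to lie between -8% and 16%.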

Compound 4, a percentage reported as inhibition, at one concentration (the size of the read-out at that concentration, not a potency): 23.6%
Beside the measured number, compound 4's estimate is 20.6 percentage points below it; the whole stated range lies below it.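

With phenoxy on the aromatic carbon, benzyl in place of tert-butoxycarbonyl gives a number 3.3 percentage points lower from compound 3 to compound 4 (within the scatter) in this assay, and this differs from the step seen with chloro at that place: the same change on two cores in this assay, a number 26.2 percentage points lower (beyond the scatter) from compound 1 to compound 2 and a number 3.3 percentage points lower (within the scatter) from compound 3 to compound 4, 22.9 percentage points apart, beyond the scatter of two such steps Read the other way, phenoxy in place of chloro gives a number 12.5 percentage points higher from compound 2 to compound 4 (beyond the scatter) when benzyl sits on the ring nitrogen, so this change does not carry over between the two tert-butoxycarbonyl and benzyl compounds either: the same change on two cores in this assay, a number 10.4 percentage points lower (beyond the scatter) from compound 1 to compound 3 and a number 12.5 percentage points higher (beyond the scatter) from compound 2 to compound 4, 22.9 percentage points apart, beyond the scatter of two such steps Both gaps come from the same four compounds, so they amount to one observation that the two changes do not simply add up; they do not show why, or how often this would happen elsewhere in the series.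

On these data alone, it remains open how a fluoro or methoxy group on that aromatic carbon would combine with benzyl on the ring nitrogen. As far as these compounds go, it is equally open whether an acetyl or methyl group on that nitrogen would follow the chloro pair, the phenoxy pair or neither.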